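This account rests on a few compounds, and the source may have more. Where it says the series, first, only, none or still open, it means among the compounds named here.

Going by the values given here, in an ADME assay on HepG2 cells (Homo sapiens) for cytotoxicity, read by CellTiter-Glo, with a stated time of 48 h (a higher number here means that more compound is tolerated, a lower number that less compound is tolerated), compound 1 `CCCCNc1nc2cc(Cl)ccc2nc1S(C)(=O)=O` gives 6310 nM and compound 2 `CS(=O)(=O)c1nc2ccc(Cl)cc2nc1NC1CCCCC1` gives 5010 nM, so compound 2 stands level with the only other measured number. Compound 3 `C[S+]([O-])c1nc2ccc(Cl)cc2nc1NC1CCCCC1` carries one change: a group of 3 heavy atoms (1 carbon, 1 oxygen, 1 sulfur; no ring) in place of a group of 4 heavy atoms (1 carbon, 2 oxygen, 1 sulfur; no ring), on an aromatic carbon, on an aromatic carbon next to the ring nitrogen. Among the compounds with values here, the only measured step, a 1.3-fold lower number from compound 1 to compound 2 (0.10 log units; within the scatter), replaces butyl on a nitrogen and leaves this carbon untouched, so it bears only indirectly and gives no direction. No step beyond the scatter is therefore expected in this assay, and the estimated step is a 1.2-fold higher number from compound 2 to compound 3 (0.08 log units; within the scatter) here. Compound 3 is expected at 6000 nM, with an estimated range of 2500 nM to 15000 nM for the coming measurement.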

Compound 3, half-maximal cytotoxic concentration: 15900 nM
Beside the measured number, compound 3's estimate is 2.7-fold (0.42 log units) below it; measured number above the stated range.
By their numbers in this assay, from the lowest: compounds 2 and 1 (each within the scatter of the next); then compound 3.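

In this assay, going by these compounds alone, the aromatic carbon next to the ring nitrogen responds to substitution, whereas the only earlier step, at the group on the amine nitrogen, stayed within the scatter. Replacing methylsulfonyl with the smaller sulfur group gives a 3.2-fold higher number from compound 2 to compound 3 (0.50 log units; beyond the scatter), so a change at this carbon alone moves the tolerated concentration beyond the scatter. Nothing shown gives a reason for this shift.

From the compounds shown here alone, whether the step holds with butyl in place of cyclohexyl remains open. So does the outcome with methylthio, an amine or a carboxylic acid on this carbon.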